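The source may report more compounds than this note shows. Statements on the series, on what has been measured and on what is new or still open speak of the compounds shown alone.

Measured so far:
- compound 1 `CN(C)c1ccc2c(=O)c(C(=O)Nc3cc(F)cc(F)c3)cn(-c3ccc(OCCCCCCC[N+]45CCN(CC4)CC5)c(Cl)c3)c2n1`: 20.5%
- compound 2 `CN(C)c1ccc2c(=O)c(C(=O)Nc3cc(F)cc(F)c3)cn(-c3ccc(OCCCCCCC[n+]4ccccc4)c(Cl)c3)c2n1`: 21.4%

In an assay on LX2 cells for inhibition of COL1A1 promoter (Homo sapiens), read by a luciferase reporter, with a stated time of 24 h, tested at 50 uM (a lower number here means a weaker effect, a higher number a stronger effect of the compound at the concentration tested), compound 2 stands highest of the two numbers, with compound 1 nearest and within the scatter. Among the compounds with values here, the only step so far, a number 0.9 percentage points higher from compound 1 to compound 2 (within the scatter), exchanged the group at the chain end and moved the read-out hardly at all.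

Compound 3 `CC[N+]1(CCCCCCCOc2ccc(-n3cc(C(=O)Nc4cc(F)cc(F)c4)c(=O)c4ccc(N(C)C)nc43)cc2Cl)CCCCC1` differs from compound 2 by a group of 8 heavy atoms (7 carbon, 1 nitrogen; one six-membered non-aromatic ring with 1 hetero atom) in place of a group of 6 heavy atoms (5 carbon, 1 nitrogen; one six-membered aromatic ring with 1 hetero atom), on a saturated chain carbon, seven bonds along the chain from an oxygen on an aromatic ring. Within the data shown here, this is a change at the same place as the single measured step, which stayed within the scatter, so no step beyond the scatter is expected, a number 0.4 percentage points lower from compound 2 to compound 3 (within the scatter). Compound 3 is therefore estimated at 21%, with a range of 12% to 30%.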

Compound 3, a percentage reported as inhibition, at one concentration (the size of the read-out at that concentration, not a potency): 50.4%
Compound 3: middle estimate off by 29.4 percentage points, on the low side; the whole stated range lies below it.
By their numbers in this assay, from the lowest: compounds 1 and 2 (each within the scatter of the next); then compound 3.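

On a saturated chain carbon, seven bonds along the chain from an oxygen on an aromatic ring, the identity of the group matters in this assay: the non-aromatic single ring of 8 heavy atoms gives a number 29 percentage points higher from compound 2 to compound 3 (beyond the scatter) and also a number 29.9 percentage points higher from compound 1 to compound 3 (beyond the scatter). The groups leaving and entering in the first of these steps both carry net charge +1, so that step involves no change in net charge. No available measurement accounts for the rise.

Open, going by these compounds, is whether an uncharged tertiary amine or a morpholine ring at this place would hold the read-out. A shorter or longer chain is equally untested among the compounds shown, and single-concentration values give no potency.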